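Changing the ring on a carbon double-bonded to nitrogen

The compounds below may be only part of what the source reports. "The series", "measured", "known", "first", "only" and "open" are said of these compounds alone.

Three compounds share a common core and differ at two places. In a functional assay on MCF7 cells (Homo sapiens) for cytotoxicity, read by MTT assay, with a stated time of 72 h (a lower number here means a stronger inhibitor, a higher number a weaker inhibitor), compound 1 `O=C(N/N=C/c1ccc(F)cc1)Nc1cc2c(Nc3ccc(F)c(Cl)c3)ncnc2cc1O[C@H]1CCOC1` gives 28200 nM. Compound 2 `O=C(N/N=C/c1cccc(Br)c1)Nc1cc2c(Nc3ccc(F)c(Cl)c3)ncnc2cc1O[C@H]1CCOC1` gives 12400 nM, and compound 3 `COc1cc2ncnc(Nc3ccc(F)c(Cl)c3)c2cc1NC(=O)N/N=C/c1cccc(Br)c1` gives 27100 nM. Among these three numbers compound 3 stands second highest: its value and that of compound 1 lie within the scatter of each other, while compound 2 sits lower by a modest but real margin.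

Compound 4 `CCN(CC)c1ccc(/C=N/NC(=O)Nc2cc3c(Nc4ccc(F)c(Cl)c4)ncnc3cc2OC)c(O)c1` has not yet been measured. It differs from compound 3 in one place: 4-(diethylamino)-2-hydroxyphenyl in place of 3-bromophenyl on a carbon with a double bond to nitrogen. Among the compounds with values here, only one measured step touches that position: a 2.3-fold lower number from compound 1 to compound 2 (0.36 log units; beyond the scatter), a modest shift when one halogen-bearing ring replaced another. The other step, a 2.2-fold higher number from compound 2 to compound 3 (0.34 log units; beyond the scatter), concerns the oxygen substituent on the aromatic ring and does not bear on the new change. Within the data shown here, the group entering compound 4 is larger and of a different kind than anything tried at that position so far, so the one relevant step is only a rough guide; a shift of modest size in either direction, or none beyond the scatter, is plausible. Compound 4 is therefore expected to give about 20000 nM, within a range from 6000 nM to 65000 nM, which would mean a 1.4-fold lower number from compound 3 to compound 4 (0.13 log units; within the scatter) as the estimated step.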

Compound 4, half-maximal inhibitory concentration: 27300 nM
Beside the measured number, compound 4's estimate is 1.4-fold (0.14 log units) below it; the measured number falls inside the stated range.
By their numbers in this assay, from the lowest: compound 2; then compounds 3, 4 and 1 (each within the scatter of the next).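

In this assay, the change at the carbon with a double bond to nitrogen gives a 1.0-fold higher number from compound 3 to compound 4 (0.00 log units; within the scatter), so 4-(diethylamino)-2-hydroxyphenyl and 3-bromophenyl cannot be told apart here. The earlier step at this position only exchanged 4-fluorophenyl for 3-bromophenyl, both rings carrying a single halogen and no hydrogen-bond donor or acceptor. This result adds that, with methyl on the oxygen on the aromatic ring, a larger group with a hydrogen-bond donor and hydrogen-bond acceptors can stand at this position without moving the number beyond the scatter, although no measurement shown explains why the number holds steady.

The diethylamino group and the hydroxyl group enter together, so the compounds shown cannot say what each does alone, or whether the two cancel each other; a phenyl ring carrying only one of them, or a plain phenyl ring, would separate these cases. Going by these compounds, it also remains open whether 4-(diethylamino)-2-hydroxyphenyl would behave the same way with oxolan-3-yl on that oxygen, and whether a ring bearing a carboxylic acid would shift the number at this position.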